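Plasma stability of ester variants on a shared core

The source may report more compounds than this note shows. Statements on the series, on what has been measured and on what is new or still open speak of the compounds shown alone.

Measured so far:
- compound 1 `CC(C)C(=O)OCOC(=O)C1=C(S[C@@H]2CN[C@H](C(=O)Nc3cccc(C(=O)O)c3)C2)[C@H](C)[C@@H]2[C@@H]([C@@H](C)O)C(=O)N12` gives 15%
- compound 2 `COC(=O)C1=C(S[C@@H]2CN[C@H](C(=O)Nc3cccc(C(=O)OC)c3)C2)[C@H](C)[C@@H]2[C@@H]([C@@H](C)O)C(=O)N12` gives 0%

Both measured compounds were run in an ADME assay on a cell-free system (plasma, Homo sapiens) for metabolic stability, read by LC-MS, with a stated time of 60 min, at 37 degrees C, tested at 50 uM; a higher number here means that more of the compound is left, a lower number that less of the compound is left. Compound 1 holds the higher of the two numbers at 15%, and compound 2 gives 0%; the gap between them lies beyond the scatter. Among the compounds with values here, no step between measured compounds that differ in only one place is available, so the two values can be read only as they stand, and the series so far offers no direct guide for a single structural change.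

Compound 3 `C[C@@H](O)[C@H]1C(=O)N2C(C(=O)OCOC(=O)OC(C)(C)C)=C(S[C@@H]3CN[C@H](C(=O)Nc4cccc(C(=O)O)c4)C3)[C@H](C)[C@H]12` has not been measured in this assay. It differs from compound 1 in one place: tert-butoxy in place of isopropyl on a carbonyl carbon. The change sits on the carbonyl carbon of the ester chain attached to the shared core, with the rest of the molecule kept as in compound 1.

Because compound 1 gives 15%, a moderate rise rather than a fall is expected, and the step of a number 13 percentage points higher from compound 1 to compound 3 (beyond the scatter) is estimated to reach just beyond the scatter. Compound 3 is expected to give 28%, with a range from 8% to 55% in this assay.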

Compound 3, percent of the compound remaining: 40%
Compound 3: the middle estimate sits 12 percentage points below what was measured; measured number inside the range.
By their numbers in this assay, from the lowest: compound 2; then compound 1; then compound 3.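

In this assay, within the data shown here, tert-butoxy in place of isopropyl on a carbonyl carbon gives a number 25 percentage points higher from compound 1 to compound 3 (beyond the scatter), the only step so far that changes a single place. It shows that the percent of compound remaining responds to a change at this carbonyl carbon, at the far end of the ester chain, while the rest of the molecule stays as in compound 1. Nothing measured here bears on how this change produces the difference.

One step cannot separate the contribution of the oxygen that enters from that of the carbon part of the group, and isopropoxy or tert-butyl on the same carbonyl carbon would pull those two apart. From the compounds shown here alone, it also remains open whether the rise extends to other groups at this place, such as an amine or a longer chain, and whether anything there can carry the value beyond that of compound 3 at 40%.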